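Carbamoyl in place of cyano on two cores

The source may hold more compounds than are shown below. What is called first, only, known or untested is meant among the compounds shown, and "the series" means these compounds.

Compound 1 `Cc1n[nH]c(C(=O)O)c1Cc1cccc(-c2ccc(C#N)cc2)c1` and compound 2 `Cc1n[nH]c(C(=O)O)c1Cc1cccc(-c2ccc(C(N)=O)cc2)c1` share one core; compound 3 `Cc1n[nH]c(C(=O)O)c1Cc1ccc(C#N)cc1` and compound 4 `Cc1n[nH]c(C(=O)O)c1Cc1ccc(C(N)=O)cc1` share a second, smaller core. The difference between the two cores is not broken down here. In an assay on isolated protein for inhibition of 2-Hydroxyacid oxidase 2 (Homo sapiens), tested at 10 uM (a higher number here means a stronger effect of the compound at the concentration tested, a lower number a weaker effect), compound 1 gives 46% and compound 2 gives 60%. Compound 3 gives 6% in this assay. The change from compound 1 to compound 2 is carbamoyl in place of cyano on an aromatic carbon and its step is a number 14 percentage points higher from compound 1 to compound 2 (beyond the scatter). The change from compound 3 to compound 4 is carbamoyl in place of cyano on an aromatic carbon, the same change on the same kind of place. Within the data shown here, for compound 4 a step of similar size is expected, a number 12 percentage points higher from compound 3 to compound 4 (beyond the scatter), because the single measured precedent is a number 14 percentage points higher from compound 1 to compound 2 (beyond the scatter); with only one precedent on a different core the size is uncertain. Compound 4 is expected to give 18% in this assay, between 4% and 36%.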

Compound 4, a percentage reported as inhibition, at one concentration (the size of the read-out at that concentration, not a potency): 8%
Estimate against measurement, compound 4: 10 percentage points above, and the stated range covers the measured number.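

In this assay, carbamoyl in place of cyano on the smaller core gives a number 2 percentage points higher from compound 3 to compound 4 (within the scatter), so this pair does not separate the two groups. Set beside the earlier step, the result gives no ground for saying that the two cores respond differently to this change: the same change on two cores in this assay, a number 14 percentage points higher (beyond the scatter) from compound 1 to compound 2 and a number 2 percentage points higher (within the scatter) from compound 3 to compound 4, 12 percentage points apart, within the scatter of two such steps. Among these compounds, it does not show that the change carries over at a fixed size: the comparison rests on one pair per core, and only the step on the larger core lies beyond the scatter.

Still open, as far as these compounds go, is whether a carboxylic acid or an amine in the place of cyano would give a step beyond the scatter on the smaller core. Also open, from the compounds shown here alone, is how either group would behave on the core of compound 1.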